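The compounds below may be only part of what the source reports. "The series", "measured", "known", "first", "only" and "open" are said of these compounds alone.

Measured compounds in a functional assay on PC-3 cells (Homo sapiens) for antiproliferative activity, read by WST assay, with a stated time of 72 h; a lower number here means a stronger inhibitor, a higher number a weaker inhibitor:
Compound 1, `CCCCCCCCCCCCCCCCCC/N=c1\nc(N)c2nc[nH]c2c(N)n1`, gives 2610 nM.
Compound 2, `CCCCCCCC/N=c1\nc(N)c2ncn(Cc3ccccc3)c2c(N)n1`, gives 5930 nM.
Compound 3, `CC/N=c1\nc(N)c2nc[nH]c2c(N)n1`, gives > 100000 nM.

Compound 3 stands apart from the other two: its result in this assay is not a number but a limit of the assay, (the limit of > 100000 nM in this assay, at which 1 of the 3 values shown sits), so all that is known is that it inhibits too weakly to be measured there. Compound 1 and compound 2, which carry much longer chains on the shared core, both give measurable numbers in this assay.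

Compound 4, `CCCCCCCC/N=c1\nc(N)c2nc[nH]c2c(N)n1`, has not yet been tested in this assay. It differs from compound 3 in one place: hexyl in place of hydrogen on a saturated chain carbon, two bonds along the chain from a double-bonded nitrogen. The chain grows, but the shared core stays unchanged.

For the measured compounds named here, no directly measured step matches this change. Still, the longer-chain compounds 1 and 2 reach measurable values, so a gain in potency of more than the scatter is expected here, in the direction of stronger inhibition. The step from compound 3 to compound 4 is estimated at an at least 16-fold lower number from compound 3 to compound 4 (1.22 log units; beyond the scatter) in this assay. Compound 4 is therefore expected to give about 6000 nM in this assay, with a likely range from 1500 nM to 40000 nM.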

Compound 4, half-maximal inhibitory concentration: "not active" (no number reported)
The entry for compound 4 holds no number; no gap can be computed for the estimate.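

In this assay, for the compounds shown here, compound 4 is reported only as "not active", with no number, so no step from compound 3 to compound 4 can be read. Compound 3 gives a limit, not a number: the limit of > 100000 nM in this assay, at which 1 of the 4 values shown sits. The compounds shown leave open how strongly compound 4 inhibits, and whether hexyl in place of hydrogen changes the result at all.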